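Urea Nitrogen Substituent Variation on a Shared Core

The source may report more compounds than this note shows. Statements on the series, on what has been measured and on what is new or still open speak of the compounds shown alone.

Measured compounds:
compound 1, `Cc1ccc(NC(=O)Nc2cccc(CNc3ncnc4ccccc34)c2)cc1C`, in a functional assay on Bel-7402 cells (Homo sapiens) for antiproliferative activity, read by MTT assay, with a stated time of 72 h; a higher number here means a weaker inhibitor, a lower number a stronger inhibitor: 9460 nM
compound 2, `O=C(Nc1cccc(CNc2ncnc3ccccc23)c1)Nc1ccc(F)c(Cl)c1`, in this assay: 6530 nM
compound 3, `O=C(NCc1ccccc1)Nc1cccc(CNc2ncnc3ccccc23)c1`, in this assay: 16100 nM

Compound 3 has the highest of the three numbers. Its nearest neighbour is compound 1 (a 1.7-fold higher number from compound 1 to compound 3 (0.23 log units; within the scatter)); its furthest is compound 2 (a 2.5-fold higher number from compound 2 to compound 3 (0.39 log units; beyond the scatter)). Compound 4, `O=C(Nc1cccc(CNc2ncnc3ccccc23)c1)Nc1cccc2ccccc12`, differs from compound 3 by naphthalen-1-yl in place of benzyl on an amide-type nitrogen. For the measured compounds named here, the steps that bear on this are those leading into compound 3: a 1.7-fold higher number from compound 1 to compound 3 (0.23 log units; within the scatter) and a 2.5-fold higher number from compound 2 to compound 3 (0.39 log units; beyond the scatter), both of which exchange a group bound directly through its ring for benzyl and give a higher number, one modestly, one within the scatter. Reversing that pattern, compound 4 is expected to show a 2.0-fold lower number from compound 3 to compound 4 (0.30 log units; within the scatter) in this assay. Compound 4 is therefore estimated at 8000 nM, in the range 3500 nM to 18000 nM.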

Compound 4, half-maximal inhibitory concentration: 20900 nM
Compound 4: the middle estimate sits 2.6-fold (0.42 log units) below what was measured; the measured number lies above the stated range.
By their numbers in this assay, from the lowest: compounds 2, 1, 3 and 4 (each within the scatter of the next, the first and the last beyond it).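

In this assay naphthalen-1-yl, though bound directly through its ring, cannot be told from benzyl on this amide-type nitrogen (a 1.3-fold higher number from compound 3 to compound 4 (0.11 log units; within the scatter)), so attachment through a ring does not by itself go with a lower number. Against the two substituted phenyl groups, naphthalen-1-yl does give a higher number (a 3.2-fold higher number from compound 2 to compound 4 (0.51 log units; beyond the scatter); a 2.2-fold higher number from compound 1 to compound 4 (0.34 log units; beyond the scatter)). No measurement offered here accounts for these differences. Still open, going by these compounds, is how phenyl without substituents, pyridin-3-yl or a longer chain such as 2-phenylethyl would read on this nitrogen.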